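A few compounds are considered here, and "the series" means these few. Any claim that something is new, unique, unknown or untested is made for them only; others in the source may bear on it.

In a functional assay on NCI-H322 cells (Homo sapiens) for antiproliferative activity (a higher number here means a weaker inhibitor of growth, a lower number a stronger inhibitor of growth), compound 1 `COCCCCCCCCCCCCCCC/C=C1/CC(CO)(COC(=O)C(C)(C)C)OC1=O` gives > 10 ug/mL, which is a limit and not a number. Compound 2 `COCCCCCCCCCCCCCCC/C=C1\CC(CO)(COC(=O)C(C)(C)C)OC1=O` gives > 10 ug/mL, also a limit. Compound 3 `CC(C)(C)C(=O)OCC1(CO)C/C(=C\CCCCCCCCCCCO)C(=O)O1` gives > 10 ug/mL, again a limit.

Compound 4 `CC(C)(C)C(=O)OCC1(CO)C/C(=C/CCCCCCCCCCCCCCC=O)C(=O)O1` carries formyl in place of methoxymethyl on a saturated chain carbon, ten or more bonds along the chain from a double-bonded chain carbon.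

Within the data shown here, two measured steps bear on this change: a step that the two limits leave unreadable from compound 1 to compound 2, and a step that the two limits leave unreadable from compound 2 to compound 3. The second is the closer guide, as it also changes the group on a saturated chain carbon. Neither has a readable size because of the limit of > 10 ug/mL in this assay, at which 3 of the 3 values shown sit. No size or direction can therefore be carried over to this assay, and compound 4 is expected to stay close to the same limit. The expected step, with no direction supported by the data, is a number no higher from compound 1 to compound 4 (the limit leaves the size open). For compound 4 the estimate is 10 ug/mL, with an expected range of 4 ug/mL to 25 ug/mL.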

Compound 4, concentration for 50% growth inhibition: > 10 ug/mL
Compound 4 was reported as a limit; the forecaster's own chance of this, stated with the estimate: 70%; the middle value sits exactly at the limit.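

In this assay, among these compounds, compound 4 gives > 10 ug/mL, a limit and not a number, so no step from compound 1 to compound 4 can be read. The compounds shown leave open how strongly each inhibits growth and whether the group at the chain end matters: the limit of > 10 ug/mL in this assay, at which 4 of the 4 values shown sit.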